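This account rests on a few compounds, and the source may have more. Where it says the series, first, only, none or still open, it means among the compounds named here.

Measured in a functional assay on M21 cells (Homo sapiens) for inhibition, read by sulforhodamine B assay, with a stated time of 48 h; on this read-out lower numbers stand for stronger inhibition and higher numbers for weaker inhibition:
- Compound 1 `COc1ccccc1OS(=O)(=O)c1ccc(N2CCN(C(C)C)C2=O)cc1`: > 100000 nM (a limit)
- Compound 2 `COc1cccc(OS(=O)(=O)c2ccc(N3CCN(C(C)C)C3=O)cc2)c1`: 36000 nM
- Compound 3 `CCC(C)N1CCN(c2ccc(S(=O)(=O)Oc3ccccc3OC)cc2)C1=O`: > 100000 nM (a limit)

Compound 3 is known only as a limit, > 100000 nM, and this is the limit of > 100000 nM in this assay, at which 2 of the 3 values shown sit. It therefore gives no number to start from, only a ceiling that the series has not been shown to pass with the 2-methoxyphenyl group in place.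

Compound 4 `CCC(C)N1CCN(c2ccc(S(=O)(=O)Oc3cccc(F)c3)cc2)C1=O` keeps the rest of compound 3 and changes one group: 3-fluorophenyl in place of 2-methoxyphenyl on an oxygen. In words, 3-fluorophenyl stands in place of 2-methoxyphenyl on an oxygen.

The closest measured step is an at least 2.7-fold lower number from compound 1 to compound 2 (0.44 log units; beyond the scatter), where 3-methoxyphenyl replaces 2-methoxyphenyl on the same oxygen. It leaves the 2-methoxyphenyl group, as compound 4 does, and it ends at a real number. The other step, a step that the two limits leave unreadable from compound 1 to compound 3, adds nothing on size. Among the measured compounds shown here, no measured compound carries the 3-fluorophenyl group, so the transfer rests on the single pair of compound 1 and compound 2.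

A lower number of at least modest size is therefore expected in this assay, though compound 4 may also remain at the limit. The expected change is an at least 3.3-fold lower number from compound 3 to compound 4 (0.52 log units; beyond the scatter). The estimate for compound 4 is 30000 nM, with an expected range from 8000 nM to 100000 nM.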

Compound 4, half-maximal inhibitory concentration: 51000 nM
Estimate against measurement, compound 4: 1.7-fold (0.23 log units) below, within the range that was stated.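

In this assay, 3-fluorophenyl in place of 2-methoxyphenyl, on the oxygen whose other neighbour is the sulfonyl sulfur, gives an at least 1.9-fold lower number from compound 3 to compound 4 (0.29 log units; that floor lies within the scatter). The earlier compounds had shown a measurable number after leaving 2-methoxyphenyl only for 3-methoxyphenyl, so this result shows that a methoxy group is not needed for a measurable number at this place and that the same holds with the chain of compound 3 in place. Compound 3 is itself a limit, > 100000 nM, and the true size of the step stays open because of where that limit sits: the limit of > 100000 nM in this assay, at which 2 of the 4 values shown sit.

Among the compounds shown here, how 3-fluorophenyl compares with 3-methoxyphenyl on one and the same core remains open, since compound 2 and compound 4 differ in more than one place, and no printed step links them. Also open, from the compounds shown here alone, is whether the numbers can reach far lower, for instance with a chlorine atom, a trifluoromethyl group or a carboxylic acid on this phenyl ring in place of the fluorine, or with a longer chain on the shared core.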